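The source may hold more compounds than are shown below. What is called first, only, known or untested is meant among the compounds shown, and "the series" means these compounds.

Compound 1 `FC(F)(F)c1cc(COCC2(c3ccccc3)CCC(N3CCCCC3)C2)cc(C(F)(F)F)c1`: in an assay on isolated protein for antagonist activity at Substance-P receptor (Homo sapiens) (a lower number here means a stronger inhibitor, a higher number a weaker inhibitor), compound 1 gives 4.7 nM.
Compound 2 `FC(F)(F)c1cc(COCC2(c3ccccc3)CCC(NC3CC3)C2)cc(C(F)(F)F)c1`: compound 2 gives 16 nM.
Compound 3 `FC(F)(F)c1cc(COCC2(c3ccccc3)CCC(NC3CC3)CC2)cc(C(F)(F)F)c1`: compound 3 gives 74 nM.

Compound 1 and compound 2 share one core and differ in a single place: piperidin-1-yl in place of cyclopropylamino on a saturated ring carbon. That change made a 3.4-fold lower number from compound 2 to compound 1 (0.53 log units; beyond the scatter). Compound 3 carries the cyclopropylamino group on a different core; how the core of compound 3 differs from the core of compound 2 is not broken down here, and compound 3 has the highest number of the three.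

Compound 4 `FC(F)(F)c1cc(COCC2(c3ccccc3)CCC(N3CCCCC3)CC2)cc(C(F)(F)F)c1` has not yet been measured. It differs from compound 3 by piperidin-1-yl in place of cyclopropylamino on a saturated ring carbon. This is the same kind of change as that between compound 2 and compound 1, but not the same: here the place is a six-membered non-aromatic ring of carbon only, three ring bonds from the ring atom that bears a large group and three ring bonds from the ring atom that bears a phenyl group, whereas in compound 2 the ring is five-membered and both distances are two ring bonds. Compound 4 is expected to show a 3.4-fold lower number from compound 3 to compound 4 (0.53 log units; beyond the scatter) in this assay, because the same kind of change earlier gave a 3.4-fold lower number from compound 2 to compound 1 (0.53 log units; beyond the scatter). Compound 4 is therefore estimated at 22 nM, within a range from 9 nM to 55 nM.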

Compound 4, half-maximal inhibitory concentration: 93 nM
The estimate for compound 4 lay 4.2-fold (0.63 log units) below the measured number; measured number outside the range, above it.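

In this assay, putting piperidin-1-yl in place of cyclopropylamino on the core of compound 3 gives a 1.3-fold higher number from compound 3 to compound 4 (0.10 log units; within the scatter), so on this core the two groups cannot be told apart. The lower number seen on the core of compound 2 does not carry over, and the two results truly differ: the same change on two cores in this assay, a 3.4-fold lower number (0.53 log units; beyond the scatter) from compound 2 to compound 1 and a 1.3-fold higher number (0.10 log units; within the scatter) from compound 3 to compound 4, 4.3-fold (0.63 log units) apart, beyond the scatter of two such steps

So in this series, the result of this change on one core cannot simply be transferred to another, but with only two pairs, the data do not show which difference between the cores matters, whether the five-membered or six-membered ring or the distances along the ring.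

On these data alone, it remains open whether another amine, such as dimethylamino or morpholin-4-yl, would also give different results on the two cores. As far as these compounds go, it is also open how a group without nitrogen, such as a hydroxyl group, would behave on that saturated ring carbon of either core.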